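Ring Swap on a Thienopyrimidine Series of Adenosine Antagonists

The source may report more compounds than this note shows. Statements on the series, on what has been measured and on what is new or still open speak of the compounds shown alone.

Three compounds sharing one core were tested in an assay on CHO-K1 cells for antagonist activity at adenosine receptor A1 (Homo sapiens), read by a beta-galactosidase reporter, with stated times of 15 min and 6 h; on this read-out lower numbers stand for stronger inhibition and higher numbers for weaker inhibition. Compound 2 `Nc1nc(-c2ccc(Cl)o2)nc2sc(CN3CC=CC3)cc12` gives 780 nM in this assay, and compound 1 `Nc1nc(-c2ccc(Cl)o2)nc2sc(CN3CCC(F)CC3)cc12` gives 1080 nM. The two differ by a group of 7 heavy atoms (5 carbon, 1 nitrogen, 1 fluorine; one six-membered non-aromatic ring with 1 hetero atom) in place of a group of 5 heavy atoms (4 carbon, 1 nitrogen; one five-membered non-aromatic ring with 1 hetero atom), on a saturated chain carbon bound to an aromatic carbon, and this step, a 1.4-fold higher number from compound 2 to compound 1 (0.14 log units; within the scatter), changes the number only within the scatter. Compound 3 `Nc1nc(-c2cccc(C(F)(F)F)c2)nc2sc(CN3CC=CC3)cc12` carries a different core than compound 2; how the two cores differ is not broken down here. Compound 3 gives 2960 nM in this assay, the highest of the three numbers, and its gaps to compound 1 and compound 2 lie beyond the scatter.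

Compound 4 `Nc1nc(-c2cccc(C(F)(F)F)c2)nc2sc(CN3CCC(F)CC3)cc12` has not been measured. It differs from compound 3 by a group of 7 heavy atoms (5 carbon, 1 nitrogen, 1 fluorine; one six-membered non-aromatic ring with 1 hetero atom) in place of a group of 5 heavy atoms (4 carbon, 1 nitrogen; one five-membered non-aromatic ring with 1 hetero atom), on a saturated chain carbon bound to an aromatic carbon, the same change that separates compound 2 from compound 1. Because the step of a 1.4-fold higher number from compound 2 to compound 1 (0.14 log units; within the scatter) stayed within the scatter, the corresponding step for compound 4 is expected to be small as well, estimated as a 1.4-fold higher number from compound 3 to compound 4 (0.13 log units; within the scatter). On this basis compound 4 is expected to give about 4000 nM in this assay, with a range estimated from 2000 nM to 8000 nM.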

Compound 4, inhibition constant: 3030 nM
For compound 4 the middle estimate is 1.3-fold (0.12 log units) above the measured one; the measured number falls inside the stated range.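

In this assay, replacing the five-membered ring group with 4-fluoropiperidin-1-yl on the second core gives a 1.0-fold higher number from compound 3 to compound 4 (0.01 log units; within the scatter), so this change stays within the scatter on that core as well. Set beside the earlier step, the two cores show no difference that can be told apart: the same change on two cores in this assay, a 1.4-fold higher number (0.14 log units; within the scatter) from compound 2 to compound 1 and a 1.0-fold higher number (0.01 log units; within the scatter) from compound 3 to compound 4, 1.4-fold (0.13 log units) apart, within the scatter of two such steps This shows that the change carried over between these two cores in this one assay, but it rests on a single pair per core and does not show that the same would hold on any other core, nor does it separate the ring size from the fluorine, which enter together.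

The compounds shown leave open whether unsubstituted piperidine, morpholine or an open-chain amine such as dimethylamine on the same saturated chain carbon would also leave the number within the scatter on either core. They also leave open whether a core bearing a group other than the chlorofuran or the trifluoromethylphenyl would follow these two.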